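The source may hold more compounds than are shown below. What is called first, only, known or untested is meant among the compounds shown, and "the series" means these compounds.

Of the compounds shown here, three have so far been tested in a functional assay on HL-60 cells (Homo sapiens) for inhibition, read by MTT assay, with a stated time of 72 h, tested at 30 uM; a higher number here means more inhibition of growth at the concentration tested, a lower number less inhibition of growth. Compound 1, `C=CCc1cc(O)c(O)c(CN2CCC(CO)CC2)c1`, gives 37.7%. Compound 2, `C=CCc1ccc(OCc2cn(-c3cc(OC)c(OC)c(OC)c3)nn2)c(O)c1`, gives 32.8%, and compound 3, `C#CCOc1ccc(CC=C)cc1O`, gives 30.7%. On paper the number of compound 1 sits at the top of the three, yet its gap to compound 2, the nearest, and to compound 3, the furthest, both fall within the usual scatter of repeated measurements, so on these data the three cannot be told apart.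

Compound 4, `C=CCc1cc(O)c(O)c(CN2CCC(Cc3ccccc3)CC2)c1`, has not yet been measured. It differs from compound 1 at one place: phenyl in place of hydroxy on a saturated chain carbon bound to a saturated ring carbon. Cut one bond further out, the same change reads hydroxymethyl to benzyl. For the measured compounds named here, no step between measured compounds shows what such a change does, so nothing measured here points to a direction. The expectation is therefore a step of a number 4.3 percentage points higher from compound 1 to compound 4 (within the scatter) no larger than the scatter, in either direction. Compound 4 is thus expected to give about 42% in this assay, within a range from 25% to 60%.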

Compound 4, percent growth inhibition at one concentration: 90.6%
Estimate against measurement, compound 4: 48.6 percentage points below, and the stated range ends below it.
By their numbers in this assay, from the lowest: compounds 3, 2 and 1 (each within the scatter of the next); then compound 4.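

In this assay, putting phenyl in place of hydroxy on a saturated chain carbon bound to a saturated ring carbon gives a number 52.9 percentage points higher from compound 1 to compound 4 (beyond the scatter). The earlier compounds shown here could not be told apart and offered no step, so they gave no sign that this place on the molecule could shift growth inhibition at all; this one change, with the rest of the core of compound 1 left as it is, shows that it can. Nothing available here explains why the step is so large.

Hydroxy leaves and the aromatic ring enters in the same change, so this step cannot show which of the two events counts. On these data alone, it remains open whether cyclohexyl at this place, or a phenyl ring carrying a carboxylic acid or an amine, would keep the higher growth inhibition.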